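The source may hold more compounds than are shown below. What is called first, only, known or untested is meant among the compounds shown, and "the series" means these compounds.

In a functional assay on EKVX cells (Homo sapiens) for inhibition (on this read-out lower numbers stand for stronger inhibition of growth and higher numbers for weaker inhibition of growth), compound 2 `O=C(/C=C/c1cccc(O)c1)c1cccc(-n2cc(-c3ccc(Cl)cc3)[nH]c2=O)c1` gives 2400 nM, the lowest number among the three measured, though compound 3 `COc1ccc(-c2cn(-c3cccc(C(=O)/C=C/c4cc(OC)c(OC)c(OC)c4)c3)c(=O)[nH]2)cc1` gives 4200 nM, within the scatter of it, while compound 1 `O=C(/C=C/c1cccc(O)c1)c1cccc(-n2cc(-c3ccccc3)[nH]c2=O)c1` gives 15600 nM, beyond the scatter. Going by the values given here, the only measured single-site step, a 6.5-fold lower number from compound 1 to compound 2 (0.81 log units; beyond the scatter), concerns chloro in place of hydrogen and does not touch the ring on the chain. Compound 4 `COc1cc(/C=C/C(=O)c2cccc(-n3cc(-c4ccc(Cl)cc4)[nH]c3=O)c2)ccc1O` differs from compound 2 by 4-hydroxy-3-methoxyphenyl in place of 3-hydroxyphenyl on a double-bonded chain carbon bound to a double-bonded chain carbon. Among the compounds with values here, no measured step bears on this change; compounds 2 and 3 merely show that different oxygen substitution on that ring gives numbers within the scatter of each other. Compound 4 is therefore expected to move by a 1.0-fold higher number from compound 2 to compound 4 (0.02 log units; within the scatter), nothing beyond the scatter. Compound 4 is estimated at 2500 nM, between 900 nM and 7000 nM.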

Compound 4, concentration for 50% growth inhibition: 9610 nM
The estimate for compound 4 lay 3.8-fold (0.58 log units) below the measured number, outside the stated range (above it).
By their numbers in this assay, from the lowest: compounds 2 and 3 (each within the scatter of the next); then compounds 4 and 1 (each within the scatter of the next).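

In this assay, going by these compounds alone, this is the first measured step at this place, and it goes beyond the scatter: 4-hydroxy-3-methoxyphenyl in place of 3-hydroxyphenyl gives a 4.0-fold higher number from compound 2 to compound 4 (0.60 log units; beyond the scatter). The ring on a double-bonded chain carbon bound to a double-bonded chain carbon therefore matters for the number even with the chloro group held fixed. Nothing shown accounts for this shift.

The compounds shown do not separate the methoxy group from the changed place of the hydroxy group. They also leave open how a ring carrying an amine or a carboxylic acid would compare.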